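A few compounds are considered here, and "the series" means these few. Any claim that something is new, unique, unknown or untested is made for them only; others in the source may bear on it.

Measured compounds in an assay on CHO cells for antagonist activity at transient receptor potential cation channel subfamily V member 1 (Homo sapiens), read by FLIPR; on this read-out lower numbers stand for stronger inhibition and higher numbers for weaker inhibition:
- compound 1 `CC(C(=O)NCc1ccc(C(F)(F)F)cc1N1CCC(C(F)(F)F)CC1)c1ccc(NS(C)(=O)=O)c(F)c1`: 0.4 nM
- compound 2 `CC(C(=O)NCc1ccc(C(F)(F)F)cc1OCc1ccccc1)c1ccc(NS(C)(=O)=O)c(F)c1`: 0.9 nM

Among the compounds with values here, compound 2 holds the higher of the two numbers so far; compound 1 is its only neighbour, and the single step between them, a 2.3-fold higher number from compound 1 to compound 2 (0.35 log units; beyond the scatter), exchanges one large group on the aromatic carbon for another and moves the number only modestly, though beyond the scatter.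

Compound 3 `CC(C(=O)NCc1ccc(C(F)(F)F)cc1SC1CCCCC1)c1ccc(NS(C)(=O)=O)c(F)c1` is not yet measured. It differs from compound 2 by cyclohexylsulfanyl in place of benzyloxy on an aromatic carbon. Within the data shown here, the one measured step bears on it only loosely: it shows that swapping a large substituent at this position, the place ortho to a large group and meta to a trifluoromethyl group, leaves the number in the same sub-nanomolar region. Among the measured compounds shown here, with no closer precedent, the expected step of no change at the digits printed from compound 2 to compound 3 (within the scatter) is none beyond the scatter. Compound 3 is therefore estimated at 0.9 nM in this assay, within a range of 0.3 nM to 3 nM.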

Compound 3, inhibition constant: 0.5 nM
Compound 3: the middle estimate sits 1.8-fold (0.26 log units) above what was measured; the measured number falls inside the stated range.
By their numbers in this assay, from the lowest: compounds 1, 3 and 2 (each within the scatter of the next, the first and the last beyond it).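

In this assay, the aromatic carbon ortho to a large group and meta to a trifluoromethyl group accepts cyclohexylsulfanyl as well as benzyloxy: a 1.8-fold lower number from compound 2 to compound 3 (0.26 log units; within the scatter) shows that, among these compounds, neither an aromatic ring in the substituent nor an oxygen link is needed to stay in this range. Against 4-(trifluoromethyl)piperidin-1-yl, a 1.3-fold higher number from compound 1 to compound 3 (0.10 log units; within the scatter) is also within the scatter, so the cyclohexylsulfanyl compound cannot be separated from either neighbour, even though the other two are separated by a 2.3-fold higher number from compound 1 to compound 2 (0.35 log units; beyond the scatter). Nothing available explains why these three substituents read so closely.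

All three substituents shown contain a six-membered ring. Open, as far as these compounds go, is whether a much smaller group at this place, such as methoxy, a primary amine or a carboxylic acid, would keep the number in this range.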